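Arylpiperazine variation on the oxazole series, T-type channel

This account rests on a few compounds, and the source may have more. Where it says the series, first, only, none or still open, it means among the compounds named here.

Compound 1 `CCCc1nc(-c2ccccc2)c(CNCCN2CCN(c3ccccc3Cl)CC2)o1` and compound 2 `CCCc1nc(-c2ccccc2)c(CNCCCN2CCN(c3cccc(F)c3)CC2)o1` share the same core and differ in the arylpiperazine end and the linker. In an assay on HEK293 cells for inhibition of Voltage-dependent T-type calcium channel subunit alpha-1G (Homo sapiens), read by patch clamp (a lower number here means a stronger inhibitor, a higher number a weaker inhibitor), compound 1 gives 4370 nM and compound 2 gives 3030 nM. Compound 2 has the lower of the two numbers, but its gap to compound 1 lies within the scatter, so the two cannot be told apart on this pair.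

Compound 3 `CCCc1nc(-c2ccccc2)c(CNCCCN2CCN(c3ccc(C(F)(F)F)cc3)CC2)o1` has not yet been measured. It keeps the core and the three-carbon linker of compound 2 and changes only the aryl group on the piperazine: 4-(trifluoromethyl)phenyl in place of 3-fluorophenyl on an amine nitrogen in a ring. For the measured compounds named here, no step between measured compounds matches this change, so there is no direct precedent in this assay for an exchange of this kind. The expectation is a small step, if any, with a slight lean toward a lower number; the estimated step from compound 2 to compound 3 is a 1.5-fold lower number from compound 2 to compound 3 (0.18 log units; within the scatter). Compound 3 is estimated at 2000 nM, with a range from 700 nM to 6000 nM.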

Compound 3, half-maximal inhibitory concentration: 7250 nM
Compound 3: middle estimate off by 3.6-fold (0.56 log units), on the low side, outside the stated range (above it).
By their numbers in this assay, from the lowest: compounds 2, 1 and 3 (each within the scatter of the next, the first and the last beyond it).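

In this assay, for the compounds shown here, the aryl group on the ring amine nitrogen is the first place where a single exchange can be read: with the shared core and the linker held constant, 4-(trifluoromethyl)phenyl in place of 3-fluorophenyl gives a 2.4-fold higher number from compound 2 to compound 3 (0.38 log units; beyond the scatter). This position is therefore not indifferent to the choice of aryl group, and this exchange moves the number toward weaker inhibition, something the earlier pair could not show, as compound 1 and compound 2 differ in more than one place and lie within the scatter of each other. Nothing at hand separates the contributions of the group's identity and its place on the phenyl ring, and no measurement bears on the reason for the step.

On these data alone, whether a plain phenyl, or a phenyl carrying a nitrile or a methoxy group, would follow the same direction remains open, so one step does not yet give a trend at this position. The linker's own contribution also remains unread, and a longer chain with the aryl group held constant would be needed to isolate it.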